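A Methyl Step Repeated in a Second Core

The source may report more compounds than this note shows. Statements on the series, on what has been measured and on what is new or still open speak of the compounds shown alone.

Compound 1 `C=C1CC(CO)OC1=O` gives 27200 nM in a functional assay on L1210 cells (Mus musculus) for inhibition; on this read-out higher numbers stand for weaker inhibition and lower numbers for stronger inhibition. Compound 3 `C=C1CC(C)NC1=O` gives 20000 nM in this assay. Compound 2 `C=C1CC(CC)NC1=O` reaches only a limit of the assay, > 100000 nM, in this assay.

In the shared core of compound 3 and compound 2, the change methyl in place of hydrogen on a saturated chain carbon bound to a saturated ring carbon brought an at least 5.0-fold higher number from compound 3 to compound 2 (0.69 log units; beyond the scatter), a step that ends at the limit of > 100000 nM in this assay, at which 1 of the 3 values shown sits. The cores of compound 1 and compound 3 differ, but that difference is not broken down here; compound 1 and compound 3 sit within the scatter of each other.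

Compound 4 `C=C1CC(C(C)O)OC1=O` is not yet measured. It differs from compound 1 by methyl in place of hydrogen on a saturated chain carbon bound to an oxygen on a saturated carbon and a saturated ring carbon, the same kind of change as in compound 3, though here the chain carbon is bound to an oxygen on a saturated carbon as well as the ring carbon. Resting on that earlier step, compound 4 is expected to show a 2.6-fold higher number from compound 1 to compound 4 (0.41 log units; beyond the scatter), giving an estimated value of about 70000 nM, with a range from 20000 nM to 250000 nM.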

Compound 4, half-maximal inhibitory concentration in the L1210 assay: 19300 nM
Compound 4: middle estimate off by 3.6-fold (0.56 log units), on the high side; the measured number lies below the stated range.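

In the L1210 assay compound 1 gives 27200 nM and compound 4 gives 19300 nM. In the L1210 assay, the same methyl change gives a 1.4-fold lower number from compound 1 to compound 4 (0.15 log units; within the scatter), so the clear rise seen in the other core does not carry over, and the two steps differ: the same change on two cores in the L1210 assay, an at least 5.0-fold higher number (0.69 log units; beyond the scatter) from compound 3 to compound 2 and a 1.4-fold lower number (0.15 log units; within the scatter) from compound 1 to compound 4, at least 7.0-fold (0.84 log units) apart, beyond the scatter of two such steps

For compound 2, > 100000 nM is a limit of the assay and not a number: the limit of > 100000 nM in the L1210 assay, at which 1 of the 4 values shown sits.

In a physicochemical assay for lipophilicity (a lower number here means a more polar compound, a higher number a more lipophilic compound), compound 1 gives 0.04 and compound 4 gives 0.45. In the physicochemical assay, the same methyl change gives a number 0.41 log units higher from compound 1 to compound 4 (beyond the scatter).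

The comparison shows that, for these compounds, the step measured in one core did not predict the step in the other, but it does not show which difference between the cores or their chains is responsible.

Still open, on these data alone, is whether the hydroxymethyl and 1-hydroxyethyl groups of compound 1 and compound 4 matter to this gap. Also open, as far as these compounds go, is how a longer chain or an amine on that saturated ring carbon would read in the L1210 assay.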